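The source may report more compounds than this note shows. Statements on the series, on what has been measured and on what is new or still open speak of the compounds shown alone.

Measured so far in an assay on H4 cells for inhibition of Fatty-acid amide hydrolase 1 (Homo sapiens); on this read-out lower numbers stand for stronger inhibition and higher numbers for weaker inhibition:

compound 1, `CCCCCCCOc1ccc(NC(=O)Oc2ccccc2F)cc1`: compound 1 gives 28 nM
compound 2, `CCCCCCCCCCCCOc1ccc(NC(=O)Oc2ccccc2F)cc1`: compound 2 gives 13 nM
compound 3, `CCCCCCOc1ccc(NC(=O)Oc2ccccc2F)cc1`: compound 3 gives 710 nM

Of these three, compound 3 carries the highest number and is therefore the weakest inhibitor here; the step of a 25-fold higher number from compound 1 to compound 3 (1.40 log units; beyond the scatter) separates it from its nearest neighbour, and the step of a 55-fold higher number from compound 2 to compound 3 (1.74 log units; beyond the scatter) from the furthest one. Both steps are large and both concern the same place on the chain that hangs from the oxygen on the aromatic ring.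

Compound 4, `CCCCCCCCCCOc1ccc(NC(=O)Oc2ccccc2F)cc1`, differs from compound 3 by butyl in place of hydrogen on a saturated chain carbon, six bonds along the chain from an oxygen on an aromatic ring. This change lengthens the chain at exactly the place where a 25-fold higher number from compound 1 to compound 3 (1.40 log units; beyond the scatter) and a 55-fold higher number from compound 2 to compound 3 (1.74 log units; beyond the scatter) were measured, and both of those lengthenings went with a much lower number. Between the longer chains themselves the difference was only a 2.2-fold lower number from compound 1 to compound 2 (0.33 log units; beyond the scatter), so most of the gain appears with the first added carbons. A large step to a lower number is therefore expected, a 39-fold lower number from compound 3 to compound 4 (1.60 log units; beyond the scatter). Compound 4 is estimated at 18 nM, with a likely range from 8 nM to 45 nM.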

Compound 4, half-maximal inhibitory concentration: 9.2 nM
Compound 4: middle estimate off by 2.0-fold (0.29 log units), on the high side; low and high end bracket the measured number.
By their numbers in this assay, from the lowest: compounds 4 and 2 (each within the scatter of the next); then compound 1; then compound 3.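

Butyl at this place on the chain gives a 77-fold lower number from compound 3 to compound 4 (1.89 log units; beyond the scatter) in this assay and so shows that the large gain already seen with other lengths also holds for a chain of intermediate length. For the compounds shown here, the gain does not end with the single extra carbon of compound 1 either: a 3.0-fold lower number from compound 1 to compound 4 (0.48 log units; beyond the scatter) is a modest step that lies beyond the usual scatter. By contrast, a 1.4-fold lower number from compound 2 to compound 4 (0.15 log units; within the scatter) stays within the scatter, so compound 2 and compound 4 cannot be ranked, and among these compounds further lengthening past compound 4 brings no readable gain. Nothing available here explains why chain length matters so strongly at this position.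

On these data alone, whether a longer chain than that of compound 2 would hold this level remains open. So does the effect of a branched chain, or of an amine or a carboxylic acid placed on the chain.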